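Undefined Stereochemistry and Expected Cytotoxicity of Compound 3

A few compounds are considered here, and "the series" means these few. Any claim that something is new, unique, unknown or untested is made for them only; others in the source may bear on it.

Measured compounds:
- compound 1, `CC(C)CC(=O)[C@@H]1O[C@@]12C(=O)C=C(Cc1ccccc1)NC2=O`: > 100000 nM
- compound 2, `CC1=CC(=O)[C@@]2(O[C@H]2C(=O)CC(C)C)C(=O)N1`: "not determined" (no result reported)

The read-out throughout is a functional assay on HCT-116 cells (Homo sapiens) for cytotoxicity, read by WST assay, with a stated time of 48 h; on this read-out lower numbers stand for stronger inhibition and higher numbers for weaker inhibition. For compound 1 the result is a limit of the assay, not a number: > 100000 nM. Within the data shown here, for compound 2 no result was reported in this assay, so it stands without a number of its own; the only value shown in the set is the limit reported for compound 1 (the limit of > 100000 nM in this assay, at which 1 of the 2 values shown sits).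

The unmeasured partner is compound 3, `CC1=CC(=O)C2(OC2C(=O)CC(C)C)C(=O)N1`. Among the measured compounds shown here, it keeps every atom and bond of compound 2; the only change is that its stereocentres are drawn without a configuration: the two compounds have the same atoms and bonds; at least one stereo element is drawn with a configuration in one of them and without one in the other: 2 of 2 stereo elements differ; a stereocentre at a saturated ring carbon is drawn R in compound 2 and without a configuration in compound 3; a stereocentre at a saturated ring carbon is drawn R in compound 2 and without a configuration in compound 3. For the measured compounds named here, with no step between measured compounds and no number for compound 2, no size or direction of change can be read from the data; the one value available is the limit of compound 1, which shares the epoxide-containing core.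

Resting on that, compound 3 is expected to give 100000 nM in this assay, within a range of 20000 nM to 300000 nM, most likely returned as a limit.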

Compound 3, half-maximal inhibitory concentration: 30400 nM
For compound 3 the middle estimate is 3.3-fold (0.52 log units) above the measured one; low and high end bracket the measured number.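

No step can be read from compound 2 to compound 3: in this assay compound 3 gives 30400 nM, while compound 2 has no number to set against it. The compounds shown leave open whether the configuration drawn at the two stereocentres of compound 2 changes the result in this assay, and which configuration or mixture compound 3 represents.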